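The source may report more compounds than this note shows. Statements on the series, on what has been measured and on what is new or still open speak of the compounds shown alone.

Compound 1 `N=C(N)N/N=C/c1c(-c2ccsc2)nc2sccn12` and compound 2 `Cc1cc(-c2nc3sccn3c2/C=N/NC(=N)N)c(C)s1` share one core, while compound 3 `N=C(N)N/N=C/c1c(-c2ccsc2)nc2n1CCS2` and compound 4 `Cc1cc(-c2nc3n(c2/C=N/NC(=N)N)CCS3)c(C)s1` share another; the difference between the two cores is not broken down here. In a functional assay on cells (Cancer cell lines, Homo sapiens) for inhibition (a lower number here means a stronger inhibitor of growth, a higher number a weaker inhibitor of growth), compound 1 gives 15100 nM. Compound 2 carries 2,5-dimethylthiophen-3-yl in place of thiophen-3-yl on an aromatic carbon and in this assay gives 15500 nM, so that a 1.0-fold higher number from compound 1 to compound 2 (0.01 log units; within the scatter). In this assay compound 3 gives 25100 nM, and its gaps to compound 1 and to compound 2 both lie within the scatter, so nothing separates the three on these numbers. Compound 4 carries 2,5-dimethylthiophen-3-yl in place of thiophen-3-yl on an aromatic carbon; the surroundings differ in that the place in compound 4 is also two ring bonds from two ring atoms that each bear a fused ring, so this is the same kind of change, not the same one. Because a 1.0-fold higher number from compound 1 to compound 2 (0.01 log units; within the scatter) stayed within the scatter on the core of compound 1, a similarly flat step is expected on the core of compound 3, so that a 1.0-fold lower number from compound 3 to compound 4 (0.00 log units; within the scatter). For compound 4 the estimate in this assay is therefore 25000 nM, with a range from 12000 nM to 55000 nM.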

Compound 4, concentration for 50% growth inhibition: 18600 nM
For compound 4 the middle estimate is 1.3-fold (0.13 log units) above the measured one; measured number inside the range.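

In this assay, placing 2,5-dimethylthiophen-3-yl in place of thiophen-3-yl on the core of compound 3 gives a 1.3-fold lower number from compound 3 to compound 4 (0.13 log units; within the scatter). Set beside the earlier step, the change behaves alike on the two cores: the same change on two cores in this assay, a 1.0-fold higher number (0.01 log units; within the scatter) from compound 1 to compound 2 and a 1.3-fold lower number (0.13 log units; within the scatter) from compound 3 to compound 4, 1.4-fold (0.14 log units) apart, within the scatter of two such steps This shows that the absence of a measurable effect carried from one core to the other, but it does not show that the change has any effect of its own on either core, and it rests on a single pair per core, so it says nothing about other substituents or other cores.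

The compounds shown carry only these two thiophene groups at this place, so it remains open whether a different kind of group there, such as a phenyl ring, an amine or a carboxylic acid, would separate the compounds in this assay. From the compounds shown here alone, it also remains open whether such a group would behave alike on both cores.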